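Chain Extension at Compound 3: Propyl to Butyl

The source may report more compounds than this note shows. Statements on the series, on what has been measured and on what is new or still open speak of the compounds shown alone.

Measured compounds:
compound 1 `C=CCc1c(SC)nc2nc(C(=O)c3ccccc3)cn2c1C` — 5 mg/kg
compound 2 `CCc1c(SC)nc2nc(C(=O)c3ccccc3)cn2c1C` — 2 mg/kg
compound 3 `CCCc1c(OC)nc2nc(C(=O)c3ccccc3)cn2c1CC` — 10 mg/kg

In a functional assay on the whole organism with Rattus norvegicus as the target (a higher number here means that more compound is needed for the effect, a lower number that less compound is needed), compound 3 gives the highest number of the three measured; it sits within the scatter of compound 1 and beyond it relative to compound 2. Within the data shown here, the one measured step, a 2.5-fold lower number from compound 1 to compound 2 (0.40 log units; beyond the scatter), concerns methyl in place of vinyl and does not touch the part changed here. Compound 4 `CCCCc1c(OC)nc2nc(C(=O)c3ccccc3)cn2c1CC` differs from compound 3 by methyl in place of hydrogen on a saturated chain carbon, three bonds along the chain from an aromatic carbon, a change from propyl to butyl. Among the measured compounds shown here, no measured step bears on it, so no shift beyond the scatter in this assay is expected, no change at the digits printed from compound 3 to compound 4 (within the scatter). Compound 4 is estimated at 10 mg/kg, with a range from 4 mg/kg to 25 mg/kg.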

Compound 4, minimum effective dose: 10 mg/kg
Estimate against measurement, compound 4: no gap at the digits printed; measured number inside the range.
By their numbers in this assay, from the lowest: compound 2; then compounds 1, 3 and 4 (each within the scatter of the next).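

In this assay, the change from propyl to butyl gives no change at the digits printed from compound 3 to compound 4 (within the scatter). Among these compounds, this is the first reading at this chain, and it shows that methyl in place of hydrogen at this place, three bonds along the chain from an aromatic carbon, is tolerated without a shift beyond the scatter. No available evidence accounts for this result. The compounds shown leave open whether a longer chain, or a chain ending in an amine or a carboxylic acid, would keep the number unchanged.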